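Varying the Aryl Amide on a Shared Core

The source may report more compounds than this note shows. Statements on the series, on what has been measured and on what is new or still open speak of the compounds shown alone.

Compound 1 `O=C(Nc1cccc(-c2oc3cc(-c4ccc(F)cc4)ccc3c(=O)c2O)c1)c1ccccc1F`: 7570 nM
Compound 2 `O=C(Nc1cccc(-c2oc3cc(-c4ccc(F)cc4)ccc3c(=O)c2O)c1)c1ccc(F)cc1`: 8590 nM
Compound 3 `O=C(Nc1cccc(-c2oc3cc(-c4ccc(F)cc4)ccc3c(=O)c2O)c1)c1ccc(Cl)cc1`: 4730 nM

The three measured compounds were tested in a functional assay on MCF7 cells (Homo sapiens) for antiproliferative activity, read by CCK-8 assay, with a stated time of 72 h; on this read-out lower numbers stand for stronger inhibition and higher numbers for weaker inhibition. Compound 3 gives the lowest number of the three, but its gaps to the others stay within the scatter: a 1.6-fold lower number from compound 1 to compound 3 (0.20 log units; within the scatter) and a 1.8-fold lower number from compound 2 to compound 3 (0.26 log units; within the scatter). Between compound 1 and compound 2 the step is also small, a 1.1-fold higher number from compound 1 to compound 2 (0.05 log units; within the scatter).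

Compound 4 `COc1ccccc1C(=O)Nc1cccc(-c2oc3cc(-c4ccc(F)cc4)ccc3c(=O)c2O)c1` has not yet been measured in this assay. It differs from compound 3 by 2-methoxyphenyl in place of 4-chlorophenyl on a carbonyl carbon. Going by the values given here, the steps that bear on this change are those within the same region, namely the move to the 4-chlorophenyl group seen in the step from compound 1 and the swap of halogen seen from compound 2; both were within the scatter. A return to a ring carrying a single substituent in the 2-position, as in compound 1, is therefore expected to produce at most a small step, a 1.5-fold higher number from compound 3 to compound 4 (0.17 log units; within the scatter), in this assay. Compound 4 is expected to give about 7000 nM, within a range from 3500 nM to 14000 nM.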

Compound 4, half-maximal inhibitory concentration: 2100 nM
The estimate for compound 4 lay 3.3-fold (0.52 log units) above the measured number; the measured number lies below the stated range.
By their numbers in this assay, from the lowest: compound 4; then compounds 3, 1 and 2 (each within the scatter of the next).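

Going by these compounds alone, this position can register a change beyond the scatter, which no step among the halogen-bearing compounds had done. Placing 2-methoxyphenyl on the carbonyl carbon in place of 4-chlorophenyl gives a 2.3-fold lower number from compound 3 to compound 4 (0.35 log units; beyond the scatter) in this assay and in place of 4-fluorophenyl gives a 4.1-fold lower number from compound 2 to compound 4 (0.61 log units; beyond the scatter) on the same read-out. The closest comparison is a swap of fluoro for methoxy, which gives a 3.6-fold lower number from compound 1 to compound 4 (0.56 log units; beyond the scatter) as a single-group change, so the identity of this substituent matters here, though nothing available explains the lower number.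

The compounds shown leave open whether the step belongs to methoxy alone or would also appear with a hydroxyl, an ethoxy group or an amine. They also leave open whether 4-methoxyphenyl would match 2-methoxyphenyl on this carbonyl carbon.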